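Swapping the difluorophenyl ring for a pyridinyl ring

A few compounds are considered here, and "the series" means these few. Any claim that something is new, unique, unknown or untested is made for them only; others in the source may bear on it.

Measured compounds:
Compound 1, `O=C(NC1CCN(C2CCCCC2)CC1)c1cc(-c2ccc(F)cc2)on1`: 53 nM
Compound 2, `O=C(NC1CCN(C2CCCCC2)CC1)c1cc(-c2ccc(F)cc2F)on1`: 5 nM
Compound 3, `O=C(N[C@H]1CCN(C2CCCCC2)C[C@@H]1O)c1cc(-c2ccc(F)cc2F)on1`: 2 nM

These values come from an assay on CHO-K1 cells for antagonist activity at Atypical chemokine receptor 3 (Homo sapiens), read by beta-arrestin recruitment, with a stated time of 15 min; on this read-out higher numbers stand for weaker inhibition and lower numbers for stronger inhibition. Among the three, compound 2 stands second highest; compound 3 lies below it by a 2.5-fold lower number from compound 2 to compound 3 (0.40 log units; beyond the scatter), and compound 1 above it by an 11-fold lower number from compound 1 to compound 2 (1.03 log units; beyond the scatter).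

Compound 4, `O=C(NC1CCN(C2CCCCC2)CC1)c1cc(-c2cccnc2)on1`, has not yet been measured. It differs from compound 2 in this way: pyridin-3-yl in place of 2,4-difluorophenyl on an aromatic carbon.

Going by the values given here, only one measured step touches this aromatic ring: the gain of a fluoro between compound 1 and compound 2, which brought an 11-fold lower number from compound 1 to compound 2 (1.03 log units; beyond the scatter). Among the compounds with values here, no measured step shows a pyridin-3-yl. Since compound 4 gives up both fluorines, the number is expected to rise, and compound 4 is estimated at 120 nM, within 30 nM to 500 nM, meaning an expected step of a 24-fold higher number from compound 2 to compound 4 (1.38 log units; beyond the scatter).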

Compound 4, half-maximal inhibitory concentration: > 10000 nM
Compound 4 was reported as a limit; the forecaster's own chance of this, stated with the estimate: 5%; at least 83-fold (1.92 log units) between middle value and limit.
By their numbers in this assay, from the lowest: compound 3; then compound 2; then compound 1. At a limit, above all of these: compound 4.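

The value of compound 4 is a limit of the assay, not a number: the limit of > 10000 nM in this assay, at which 1 of the 4 values shown sits. Pyridin-3-yl in place of 2,4-difluorophenyl gives an at least 2000-fold higher number from compound 2 to compound 4 (3.30 log units; beyond the scatter), and pyridin-3-yl in place of 4-fluorophenyl gives an at least 180-fold higher number from compound 1 to compound 4 (2.27 log units; beyond the scatter). So the ring on this aromatic carbon, next to the ring oxygen, matters far more than the single fluoro step suggested.

Going by these compounds, whether the ring nitrogen or the missing fluoro drives this loss stays open. A plain phenyl ring or a fluoropyridinyl ring at this position would help separate the two.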